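Aryl swap on the triazole of compound 1

The compounds below may be only part of what the source reports. "The series", "measured", "known", "first", "only" and "open" are said of these compounds alone.

Measured compounds:
Compound 1, `Cc1ccccc1-n1cc(CN2C(=O)C[C@@H]3CC[C@@]2(C)C3(C)C)nn1`, gives 350 nM in a functional assay on SGC-7901 cells (Homo sapiens) for inhibition, read by MTT assay, with a stated time of 24 h; on this read-out higher numbers stand for weaker inhibition and lower numbers for stronger inhibition.
Compound 2, `CC1(C)[C@H]2CC[C@]1(C)N(Cc1cn(-c3ccccc3)nn1)C(=O)C2`, gives 240 nM in this assay.
Compound 3, `CC1(C)[C@H]2CC[C@]1(C)N(Cc1cn(-c3cccc(O)c3)nn1)C(=O)C2`, gives 270 nM in this assay.

Compound 1 stands at the highest of the three numbers, though its nearest neighbour is compound 3, at a 1.3-fold lower number from compound 1 to compound 3 (0.11 log units; within the scatter), and the furthest is compound 2, at a 1.5-fold lower number from compound 1 to compound 2 (0.16 log units; within the scatter), so all three sit within the scatter of one another. The unmeasured compound 4, `CC1(C)[C@H]2CC[C@]1(C)N(Cc1cn(-c3ccc(Br)cc3)nn1)C(=O)C2`, departs from compound 1 by the change (4-bromophenyl in place of 2-methylphenyl on an aromatic nitrogen). Within the data shown here, two measured steps bear on it, since both alter the same aryl group on the triazole nitrogen: a 1.5-fold lower number from compound 1 to compound 2 (0.16 log units; within the scatter) and a 1.3-fold lower number from compound 1 to compound 3 (0.11 log units; within the scatter). Neither exceeded the scatter, and the gap between them, seen in a 1.1-fold higher number from compound 2 to compound 3 (0.05 log units; within the scatter), was likewise small. It is therefore expected that compound 4 shows no step beyond the scatter in this assay, the estimated step being a 1.2-fold lower number from compound 1 to compound 4 (0.08 log units; within the scatter). The estimate for compound 4 is 290 nM, with a range from 130 nM to 650 nM.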

Compound 4, half-maximal inhibitory concentration: 450 nM
Beside the measured number, compound 4's estimate is 1.6-fold (0.19 log units) below it, within the range that was stated.
By their numbers in this assay, from the lowest: compounds 2, 3, 1 and 4 (each within the scatter of the next).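

With 4-bromophenyl on the aromatic nitrogen, the read-out in this assay stays within the scatter of all three earlier compounds: a 1.3-fold higher number from compound 1 to compound 4 (0.11 log units; within the scatter), a 1.7-fold higher number from compound 3 to compound 4 (0.22 log units; within the scatter) and a 1.9-fold higher number from compound 2 to compound 4 (0.27 log units; within the scatter). The last of these, bromo in place of hydrogen on an aromatic carbon, is the largest step yet seen at this position, and it still does not exceed the scatter, so 2-methylphenyl, phenyl, 3-hydroxyphenyl and 4-bromophenyl cannot be told apart here. Nothing available bears on the reason for this result.

The compounds shown leave open whether an amine or a carboxylic acid on the aryl ring, or a longer chain in place of that ring, would move the number beyond the scatter. As far as these compounds go, they also cover only this one cell line, so whether the same holds in other cells remains open.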